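The compounds below may be only part of what the source reports. "The series", "measured", "known", "first", "only" and "open" are said of these compounds alone.

Three compounds of this series carry a value in a functional assay on PC-3 cells (Homo sapiens) for cytotoxicity, read by MTT assay, with a stated time of 72 h (a higher number here means a weaker inhibitor, a lower number a stronger inhibitor), and one awaits measurement. Compound 1 `O=C(Nc1ccc(Oc2ccnc3[nH]ccc23)c(F)c1)c1nn(-c2ccc(Br)cc2F)ccc1=O` gives 8800 nM in this assay. Compound 2 `COc1ccc(-n2ccc(=O)c(C(=O)Nc3ccc(Oc4ccnc5c4ccn5C)cc3)n2)cc1` gives only a limit of the assay, > 60000 nM. Compound 3 `Cc1cc(=O)n(-c2ccc(F)cc2)nc1C(=O)Nc1ccc(Oc2ncnc3[nH]ccc23)cc1` likewise gives only a limit, > 60000 nM, so its place in this assay is known only as the weak end of what the method reports, a point stressed by the limit of > 60000 nM in this assay, at which 2 of the 3 values shown sit.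

Compound 4 `Cc1cc(=O)n(-c2cccc(C(F)(F)F)c2)nc1C(=O)Nc1ccc(Oc2ncnc3[nH]ccc23)cc1` differs from compound 3 in one place: 3-(trifluoromethyl)phenyl in place of 4-fluorophenyl on an aromatic nitrogen. No measured pair in this set shares this change, so its size in this assay cannot be read from the data; with compound 3 at the limit, the shown values give no direction to lean on.

Compound 4 is therefore expected to stay near that limit in this assay, with the step from compound 3 estimated as a number no higher from compound 3 to compound 4 (the limit leaves the size open). The estimate for compound 4 is 60000 nM, in a range of 20000 nM to 200000 nM.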

Compound 4, half-maximal inhibitory concentration: 3460 nM
Compound 4: middle estimate off by 17-fold (1.24 log units), on the high side; measured number below the stated range.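

In this assay the group on the aromatic nitrogen is shown to matter: with the rest of the molecule unchanged, 3-(trifluoromethyl)phenyl in place of 4-fluorophenyl gives an at least 17-fold lower number from compound 3 to compound 4 (1.23 log units; beyond the scatter). Among these compounds, the earlier compounds held no pair differing in one place; this is the first readable step, and it moves a compound off the weak limit through a change at this position alone. The true size of the step stays open, since compound 3 carries only a limit and the step is therefore a lower bound: the limit of > 60000 nM in this assay, at which 2 of the 4 values shown sit.

Among the compounds shown here, the single step does not separate the place of the substituent from its identity: 4-fluorophenyl and 3-(trifluoromethyl)phenyl differ in both. Whether an amine or a carboxylic acid on this phenyl ring would keep the lower number, and whether the step carries over to the core of compound 1, remains unanswered.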